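The source may hold more compounds than are shown below. What is called first, only, known or untested is meant among the compounds shown, and "the series" means these compounds.

Measured so far:
Compound 1, `Cn1cc(C2=C(c3nn(CCCN4CCCCC4)c4ncccc34)C(=O)N(c3ccccc3)C2=O)c2ccccc21`, in a functional assay on K562 cells (Homo sapiens) for antiproliferative activity, read by MTT assay, with a stated time of 48 h (on this read-out higher numbers stand for weaker inhibition and lower numbers for stronger inhibition), gives 3790 nM.
Compound 2, `Cn1cc(C2=C(c3nn(CCCN4CCCCC4)c4ncccc34)C(=O)N(c3ccc(Cl)cc3)C2=O)c2ccccc21`, in this assay gives 1800 nM.
Compound 3, `Cn1cc(C2=C(c3nn(CCCN4CCCCC4)c4ncccc34)C(=O)N(c3ccccn3)C2=O)c2ccccc21`, in this assay gives > 100000 nM, which is a limit of the assay and not a number.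

Compound 3 therefore stands at the weak end of the three, with only a limit to show, as the reading the limit of > 100000 nM in this assay, at which 1 of the 3 values shown sits, tells. Against compound 1 the step was an at least 26-fold higher number from compound 1 to compound 3 (1.42 log units; beyond the scatter), and against compound 2 it was an at least 55-fold higher number from compound 2 to compound 3 (1.74 log units; beyond the scatter). Between compound 1 and compound 2 the step was a 2.1-fold lower number from compound 1 to compound 2 (0.32 log units; beyond the scatter).

Compound 4, `COc1ccc(N2C(=O)C(c3cn(C)c4ccccc34)=C(c3nn(CCCN4CCCCC4)c4ncccc34)C2=O)cc1`, has not yet been measured. It differs from compound 3 in a single place: 4-methoxyphenyl in place of pyridin-2-yl on an amide-type nitrogen in a ring. This puts a six-membered aromatic ring of carbon only back on the amide-type nitrogen in a ring, as compound 1 and compound 2 carry there, where compound 3 carries the pyridin-2-yl. The two steps that bear on the change are those from compound 1 and from compound 2 to compound 3, both large increases; walked in the opposite direction, a large decrease is expected in this assay. Compound 4 is thus expected to give 3000 nM, within 1000 nM to 10000 nM, which is an expected step of an at least 33-fold lower number from compound 3 to compound 4 (1.52 log units; beyond the scatter).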

Compound 4, half-maximal inhibitory concentration: > 100000 nM
Compound 4: no number, only a limit; the forecaster's own chance of this, stated with the estimate: 5%; at least 33-fold (1.52 log units) between middle value and limit.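

In this assay compound 4 gives > 100000 nM, which is a limit of the assay and not a number. For the compounds shown here, a single group on the phenyl ring now decides the outcome: methoxy in place of hydrogen gives an at least 26-fold higher number from compound 1 to compound 4 (1.42 log units; beyond the scatter), and methoxy in place of chloro gives an at least 55-fold higher number from compound 2 to compound 4 (1.74 log units; beyond the scatter), so a six-membered aromatic ring of carbon only on the amide-type nitrogen does not by itself keep the activity seen with compound 1 and compound 2, and the pyridin-2-yl of compound 3 is no longer the only group at this position tied to such a large rise in the number. Compound 3 and compound 4 cannot be put in order, and the step between them cannot be read, since both rest on the same limit: the limit of > 100000 nM in this assay, at which 2 of the 4 values shown sit.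

The compounds shown leave open how far above the limit compound 3 and compound 4 really lie, and so which of the two is the weaker. They also leave open whether the loss belongs to methoxy in particular, which a methyl, a fluoro or a hydroxy group on the same ring carbon would test.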